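A few compounds are considered here, and "the series" means these few. Any claim that something is new, unique, unknown or untested is made for them only; others in the source may bear on it.

Compound 1 `COc1ccc(C(=O)/C=C/c2cn(-c3ccccc3)nc2-c2ccsc2)c(OC)c1` gives 9000 nM in a functional assay on MCF7 cells (Homo sapiens) for inhibition, read by sulforhodamine B assay, with a stated time of 72 h; a lower number here means a stronger inhibitor, a higher number a weaker inhibitor.
Compound 2 `O=C(/C=C/c1cn(-c2ccccc2)nc1-c1cccnc1)c1cc[nH]c1` gives 6900 nM in this assay.
Compound 3 `COc1ccc(C(=O)/C=C/c2cn(-c3ccccc3)nc2-c2cccnc2)c(OC)c1OC` gives 1400 nM in this assay.

Among the three measured compounds, compound 3 gives the lowest half-maximal inhibitory concentration in this assay. Its nearest neighbour is compound 2, whose number is higher by an amount beyond the usual scatter, and compound 1 lies furthest away, also beyond the scatter. Compound 3 therefore stands as the strongest inhibitor of the measured set.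

Compound 4 `COc1ccc(C(=O)/C=C/c2cn(-c3ccccc3)nc2-c2cccnc2)c(OC)c1` has not yet been measured. It differs from compound 3 in one place: hydrogen in place of methoxy on an aromatic carbon. The change is a hydrogen in place of methoxy on an aromatic carbon, sitting ortho to two methoxy groups and meta to a large group on a six-membered aromatic ring of carbon only.

Going by the values given here, no measured pair shows this exact change, so its size in this assay cannot be read directly. Among the compounds with values here, the only dimethoxy compound in the set, compound 1, gives a markedly higher number than compound 3, but it also differs in another part of the structure, so that comparison is only suggestive. The step from compound 3 to compound 4 is expected to raise the number moderately, by a 2.9-fold higher number from compound 3 to compound 4 (0.46 log units; beyond the scatter). Compound 4 is therefore estimated to give about 4000 nM, with a likely range from 1500 nM to 12000 nM.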

Compound 4, half-maximal inhibitory concentration: 2300 nM
Beside the measured number, compound 4's estimate is 1.7-fold (0.24 log units) above it; the measured number falls inside the stated range.
By their numbers in this assay, from the lowest: compounds 3 and 4 (each within the scatter of the next); then compounds 2 and 1 (each within the scatter of the next).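

With hydrogen in place of methoxy on the aromatic carbon ortho to two methoxy groups, this assay shows a 1.6-fold higher number from compound 3 to compound 4 (0.22 log units; within the scatter), so the loss of this methoxy group produces no change beyond the usual scatter. The new compound also gives the first one-place links to the other measured compounds, and 2,4-dimethoxyphenyl in place of 1H-pyrrol-3-yl on the carbonyl carbon gives a 3.0-fold lower number from compound 2 to compound 4 (0.48 log units; beyond the scatter). Pyridin-3-yl in place of thiophen-3-yl on an aromatic carbon gives a 3.9-fold lower number from compound 1 to compound 4 (0.59 log units; beyond the scatter), so this exchange alone gives a step beyond the scatter, with the methoxy group at the position in question absent from both compounds.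

Going by these compounds, it remains open whether a hydroxy group, a fluorine atom or an amine at this position would also leave the number within the scatter, and whether the same loss of methoxy would give a similar step with thiophen-3-yl in place of pyridin-3-yl. Nothing in the available data explains the size of any of these steps.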